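The compounds below may be only part of what the source reports. "The series", "measured", "known", "first", "only" and "open" are said of these compounds alone.

Working notes on the cyanoguanidine series in a functional assay on Sf9 cells for antagonist activity at histamine H2 receptor (Homo sapiens), read by scintillation counting and GTPgammaS binding, with a stated time of 90 min; on this read-out higher numbers stand for higher potency (the scale is a negative logarithm) and lower numbers for lower potency.

Compound 1 `N#C/N=C(\NCCNc1ccnc(N)n1)NCCSc1ccccc1` gives in this assay only a limit, < 5. Compound 2 `CN/C(=N/C#N)NCCCCCn1ccnc1C` likewise gives a limit, < 5. Compound 3 `Cc1nccn1CCCCCN/C(=N\C#N)NCCSc1ccccc1` also returns a limit in this assay, < 5. Within the data shown here, the single measured step, a step that the two limits leave unreadable from compound 2 to compound 3, cannot be sized, since both ends are limits. The position of compound 3 is therefore set only by the limit of < 5 in this assay, at which 3 of the 3 values shown sit: it sits at the same limit as the other two, with no number to rank it against them.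

Compound 4 `N#C/N=C(\NCCCNc1nc(N)n[nH]1)NCCSc1ccccc1` differs from compound 3 by (3-amino-1H-1,2,4-triazol-5-yl)amino in place of 2-(2-methyl-1H-imidazol-1-yl)ethyl on a saturated chain carbon, three bonds along the chain from an amine nitrogen. Among the measured compounds shown here, no measured step bears on this change; the only recorded step concerns a different group and is itself unreadable, so no direction or size can be drawn from the measured set.

Compound 4 is therefore expected near the limit, at 5, with a range from 4.3 to 5.8. The corresponding expected step is a number no lower from compound 3 to compound 4 (the limit leaves the size open), which rests on the shared limit rather than on any readable trend.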

Compound 4, negative logarithm of the antagonist equilibrium constant: < 5
Compound 4: a limit, no number (the forecaster's own chance of this, stated with the estimate: 55%); the middle value sits exactly at the limit.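

The steps from compound 3 and from compound 1 to compound 4 cannot be read, since each has a limit at both ends: the limit of < 5 in this assay, at which 4 of the 4 values shown sit.

The compounds shown leave open how these four rank against one another, and whether any change on the shared core gives a readable potency.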